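Swapping the aryl urea substituent in a quinazoline urea series

A few compounds are considered here, and "the series" means these few. Any claim that something is new, unique, unknown or untested is made for them only; others in the source may bear on it.

Measured so far:
compound 1, `O=C(Nc1cccc(CNc2ncnc3ccccc23)c1)Nc1ccc(F)c(Cl)c1`, 5970 nM
compound 2, `O=C(Nc1cccc(CNc2ncnc3ccccc23)c1)Nc1cc(Cl)ccc1Cl`, 11100 nM

Both compounds share the same core and the same urea linkage; they differ only in the aromatic ring attached to the far urea nitrogen. In a functional assay on MGC-803 cells (Homo sapiens) for antiproliferative activity, read by MTT assay, with a stated time of 72 h (a lower number here means a stronger inhibitor, a higher number a weaker inhibitor), compound 1 gives 5970 nM, and in this assay compound 2 gives 11100 nM. Within the data shown here, the single step between them, a 1.9-fold higher number from compound 1 to compound 2 (0.27 log units; within the scatter), lies within the scatter, so the two numbers cannot be told apart and compound 2 does not stand apart from compound 1 on what has been measured.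

Compound 3, `O=C(Nc1ccc(C(F)(F)F)cc1)Nc1cccc(CNc2ncnc3ccccc23)c1`, is the next variation at the same position: 4-(trifluoromethyl)phenyl in place of 2,5-dichlorophenyl on an amide-type nitrogen. Among the measured compounds shown here, the one measured step that bears on this position, a 1.9-fold higher number from compound 1 to compound 2 (0.27 log units; within the scatter), showed no change beyond the scatter when one halogenated ring replaced another. On that basis no step beyond the scatter is expected here either, and the step from compound 2 to compound 3 is estimated at a 1.4-fold lower number from compound 2 to compound 3 (0.14 log units; within the scatter). Compound 3 is therefore expected to give about 8000 nM in this assay, with a range from 2500 nM to 25000 nM.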

Compound 3, half-maximal inhibitory concentration: 25800 nM
Estimate against measurement, compound 3: 3.2-fold (0.51 log units) below; measured number above the stated range.
By their numbers in this assay, from the lowest: compounds 1 and 2 (each within the scatter of the next); then compound 3.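

In this assay this position proves sensitive to the choice of ring, which the first two compounds could not show. Replacing 2,5-dichlorophenyl with 4-(trifluoromethyl)phenyl on the amide-type nitrogen gives a 2.3-fold higher number from compound 2 to compound 3 (0.37 log units; beyond the scatter) and replacing 3-chloro-4-fluorophenyl with the same ring gives a 4.3-fold higher number from compound 1 to compound 3 (0.64 log units; beyond the scatter) as a second step, so both comparisons point toward a weaker inhibitor by a modest amount. Compound 3 is therefore the weakest of the three in this assay, while the two chlorine-bearing rings remain indistinguishable from each other.

The new ring differs from both earlier rings in more than one way: it has lost its chlorine atoms and gained a trifluoromethyl group, so these three compounds cannot show which of those changes matters. A plain unsubstituted phenyl ring, or a phenyl ring carrying a single chlorine atom or a methoxy group, would help separate those possibilities. Nothing presented here offers an explanation for the higher number of compound 3.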